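The source may hold more compounds than are shown below. What is called first, only, known or untested is meant among the compounds shown, and "the series" means these compounds.

Within the data shown here, in an assay for inhibition of Thromboxane-A synthase (Homo sapiens), using microsomes (on this read-out lower numbers stand for stronger inhibition and higher numbers for weaker inhibition), compound 2 `CC(C)(Oc1ccccc1F)C1OCC(C/C=C\CCC(=O)O)C(c2cccnc2)O1` gives 45 nM, the smaller of the two numbers measured so far, by a margin that lies within the scatter. The other number belongs to compound 1 `CC(C)(Oc1ccc(F)cc1)C1OCC(C/C=C\CCC(=O)O)C(c2cccnc2)O1`, which gives 51 nM; the step of a 1.1-fold lower number from compound 1 to compound 2 (0.05 log units; within the scatter) is within the scatter, so the two compounds cannot be told apart on this read-out. Compound 3 `COc1ccccc1OC(C)(C)C1OCC(C/C=C\CCC(=O)O)C(c2cccnc2)O1` has not yet been measured. It differs from compound 2 by methoxy in place of fluoro on an aromatic carbon. Among the measured compounds shown here, no measured step bears directly on this kind of exchange: the only step measured, from compound 1 to compound 2, moves the fluoro group from one place on the ring to another and changes the number by less than the scatter. With nothing pointing in either direction, the expectation for compound 3 is a step that stays within the scatter, and a 1.1-fold higher number from compound 2 to compound 3 (0.05 log units; within the scatter) expresses that. Compound 3 is therefore estimated at 50 nM in this assay, with a range from 20 nM to 130 nM that allows for the usual spread of repeated measurements and for the absence of any direct precedent.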

Compound 3, half-maximal inhibitory concentration: 60 nM
The estimate for compound 3 lay 1.2-fold (0.08 log units) below the measured number; measured number inside the range.
By their numbers in this assay, from the lowest: compounds 2, 1 and 3 (each within the scatter of the next).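

In this assay the exchange of fluoro for methoxy on the aromatic carbon ortho to a large group gives a 1.3-fold higher number from compound 2 to compound 3 (0.12 log units; within the scatter) and stays within the scatter, so at this position two heavy atoms and a hydrogen-bond acceptor can stand in place of a single fluorine without a change that this read-out can detect. The earlier compounds shown here varied only where the fluoro group sat, whereas 2-methoxyphenyl in place of 4-fluorophenyl changes both the group and its place on the ring and gives a 1.2-fold higher number from compound 1 to compound 3 (0.07 log units; within the scatter), again within the scatter. No measurement is available to explain why these numbers lie so close together.

The compounds shown leave open how far this tolerance reaches, since a hydroxyl, an amine, a carboxylic acid or a longer chain such as butoxy on the same carbon could still move the number beyond the scatter. They also leave open whether methoxy would behave the same way at the place that fluoro holds in compound 1.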